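A few compounds are considered here, and "the series" means these few. Any claim that something is new, unique, unknown or untested is made for them only; others in the source may bear on it.

Measured so far in a functional assay on HeLa cells (Homo sapiens) for inhibition, read by CCK-8 assay, with a stated time of 72 h; on this read-out lower numbers stand for stronger inhibition and higher numbers for weaker inhibition:
- compound 1 `O=C(/C=C/c1cccnc1)NCCCCCCc1cccc(S(=O)(=O)Nc2ccccc2)c1`: 30.4 nM
- compound 2 `CC(C)(C)c1ccc(NS(=O)(=O)c2cccc(CCCCCCNC(=O)/C=C/c3cccnc3)c2)cc1`: 1520 nM

Compound 2 holds the higher of the two numbers, so it is the weaker of the pair on this read-out. Compound 3 `O=C(/C=C/c1cccnc1)NCCCCCCc1cccc(S(=O)(=O)Nc2ccc(Cl)cc2)c1` carries chloro in place of tert-butyl on an aromatic carbon, para to a large group: chloro in place of tert-butyl on an aromatic carbon. Going by the values given here, one measured step bears on this change, at the same ring carbon: a 50-fold higher number from compound 1 to compound 2 (1.70 log units; beyond the scatter), where tert-butyl replaced hydrogen. With hydrogen there, compound 1 gives 30.4 nM. Among the compounds with values here, removing the tert-butyl is therefore expected to bring the number down substantially in this assay, although no chloro compound has been measured to show how far. The estimate amounts to a 17-fold lower number from compound 2 to compound 3 (1.23 log units; beyond the scatter), an expected large step towards stronger inhibition. For compound 3 the expected value is 90 nM, with an estimated range of 25 nM to 400 nM.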

Compound 3, half-maximal inhibitory concentration: 170 nM
Compound 3: middle estimate off by 1.9-fold (0.28 log units), on the low side, within the range that was stated.
By their numbers in this assay, from the lowest: compound 1; then compound 3; then compound 2.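

In this assay, chloro in place of tert-butyl gives an 8.9-fold lower number from compound 2 to compound 3 (0.95 log units; beyond the scatter) at this ring carbon, so much of the loss tied to tert-butyl does not persist with the smaller group. Chloro still does not match hydrogen, giving a 5.6-fold higher number from compound 1 to compound 3 (0.75 log units; beyond the scatter) and showing that this position is sensitive to more than the bulkiest group. Across these three compounds the number rises from hydrogen to chloro to tert-butyl, but no measurement at hand accounts for that order.

The compounds shown leave open where a methoxy, an amine or a carboxylic acid at this ring carbon would fall relative to hydrogen and chloro. They also leave open whether any group here can equal or improve on hydrogen, and whether chloro would give the same result at another carbon of this ring.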